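Amide nitrogen substituent swap in the aryl acetamide series

The source may hold more compounds than are shown below. What is called first, only, known or untested is meant among the compounds shown, and "the series" means these compounds.

Compound 1 `Cc1ccc(OCC(=O)N(Cc2cccs2)c2ccnn2C)cc1` gives 422 nM in an assay on HEK293 cells for agonist activity at transient receptor potential cation channel subfamily M member 8 (Homo sapiens), read by fluorescence and calcium flux, with a stated time of 15 min (a lower number here means that less compound is needed, a higher number that more compound is needed for the effect), the highest of the two numbers recorded. Compound 2 `Cc1ccc(/C=C/C(=O)N(Cc2cccs2)c2ccn[nH]2)cc1` gives 0.004 nM in this assay, a far lower number, beyond the usual scatter. Compound 3 `Cc1ccc(OCC(=O)N(CCO)Cc2cccs2)cc1` differs from compound 1 by 2-hydroxyethyl in place of 1-methyl-1H-pyrazol-5-yl on an amide-type nitrogen. Within the data shown here, no measured pair shows this change, so its size is open. A modest rise in number is expected, since compound 1 already stands at 422 nM and the change removes the aromatic group on the amide nitrogen. The step from compound 1 to compound 3 is estimated at a 3.6-fold higher number from compound 1 to compound 3 (0.55 log units; beyond the scatter). Compound 3 is expected to give 1500 nM, within a range of 300 nM to 8000 nM.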

Compound 3, half-maximal effective concentration: 900 nM
Beside the measured number, compound 3's estimate is 1.7-fold (0.22 log units) above it; the measured number falls inside the stated range.
By their numbers in this assay, from the lowest: compound 2; then compound 1; then compound 3.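

In this assay, 2-hydroxyethyl in place of 1-methyl-1H-pyrazol-5-yl on the amide-type nitrogen gives a 2.1-fold higher number from compound 1 to compound 3 (0.33 log units; beyond the scatter). The five-membered aromatic ring at this position is therefore not required for agonist activity, as the open chain with no ring keeps a response at a modest cost. Nothing available explains the size of this step. On these data alone, whether the same change carries over to the core of compound 2 remains open. Also open, as far as these compounds go, is how a longer chain, or a chain ending in an amine or a carboxylic acid, would fare on this nitrogen.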